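This account rests on a few compounds, and the source may have more. Where it says the series, first, only, none or still open, it means among the compounds named here.

Working notes on the series. Compound 2 `Cc1ccc(OCC(=O)NNC(=O)c2cc3ccccc3oc2=O)c(C(=O)c2cccc(Br)c2)c1` stands highest of the two numbers recorded so far: in a functional assay on DLA cells (Mus musculus) for cytotoxicity, read by MTT assay, with a stated time of 48 h (on this read-out higher numbers stand for weaker inhibition and lower numbers for stronger inhibition), compound 2 gives 68500 nM. Its nearest neighbour is compound 1 `Cc1ccc(OCC(=O)NNC(=O)c2cc3ccccc3oc2=O)c(C(=O)c2ccccc2Cl)c1`, which in this assay gives 53800 nM; the step of a 1.3-fold higher number from compound 1 to compound 2 (0.10 log units; within the scatter) stays within the scatter, so the two are not distinguishable on this read-out.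

Compound 3 `Cc1ccc(C(=O)c2cc(C)ccc2OCC(=O)NNC(=O)c2cc3ccccc3oc2=O)cc1` is still to be measured. It differs from compound 2 in one place: 4-methylphenyl in place of 3-bromophenyl on a carbonyl carbon. Within the data shown here, the same position, the aryl group on the carbonyl carbon, is the only one that has been varied so far, and the single measured step there, a 1.3-fold higher number from compound 1 to compound 2 (0.10 log units; within the scatter), did not move the number beyond the scatter. Among the measured compounds shown here, no further step bears on the change, and the move to a methyl-bearing ring has no precedent among the measured compounds. On that basis no shift beyond the scatter is expected in this assay for compound 3: the estimated step is a 1.1-fold lower number from compound 2 to compound 3 (0.06 log units; within the scatter). Compound 3 is therefore expected to give about 60000 nM, with a range from 25000 nM to 150000 nM.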

Compound 3, half-maximal inhibitory concentration: 84600 nM
For compound 3 the middle estimate is 1.4-fold (0.15 log units) below the measured one, and the stated range covers the measured number.
By their numbers in this assay, from the lowest: compounds 1, 2 and 3 (each within the scatter of the next).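

In this assay, the aryl group on the carbonyl carbon now has a third member, and 4-methylphenyl in place of 3-bromophenyl stays within the scatter (a 1.2-fold higher number from compound 2 to compound 3 (0.09 log units; within the scatter)), as does 4-methylphenyl in place of 2-chlorophenyl (a 1.6-fold higher number from compound 1 to compound 3 (0.20 log units; within the scatter)). The earlier pair held only halogen-bearing rings, whereas this ring carries a methyl group and no halogen, and the read-out still does not separate the three aryl groups, so the insensitivity seen in the single earlier step now holds across all three pairs of these compounds. Nothing on hand offers an explanation for this result.

Going by these compounds, whether any group on the carbonyl carbon can move the number beyond the scatter stays open, for instance a phenyl ring bearing an amine or a carboxylic acid, or a longer alkyl chain in place of the ring. Only this one position differs among the compounds shown, and the effect of changes elsewhere on the shared core also remains open.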